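Methyl on the saturated ring carbon: a second look

This account rests on a few compounds, and the source may have more. Where it says the series, first, only, none or still open, it means among the compounds named here.

Working notes on a small series of prostaglandin-like acids measured in a functional assay on the whole organism (stomach) for inhibition, with Rattus norvegicus as the target; on this read-out higher numbers stand for an effect only at larger amounts of compound and lower numbers for an effect already at smaller amounts. Compound 1 `O=C(O)CCC/C=C1\CC2C[C@@H](O)[C@H](/C=C/[C@@H](O)C3COc4ccccc4O3)C2C1` gives 0.0045 mg/kg in this assay. Compound 2 `CC1([C@H](O)/C=C/[C@@H]2C3C/C(=C/CCCC(=O)O)CC3C[C@H]2O)COc2ccccc2O1` differs from it by methyl in place of hydrogen on a saturated ring carbon and gives 0.0142 mg/kg in this assay; the step of a 3.2-fold higher number from compound 1 to compound 2 (0.50 log units; beyond the scatter) is the only one of its kind that has been measured. Compound 3 `O=C(O)COCCC1=C[C@H]2C[C@@H](O)[C@H](/C=C/[C@@H](O)C3Cc4ccccc4C3)C2C1` gives 0.0274 mg/kg in this assay; the difference between its core and the core of compound 1 is not broken down here, and its value and that of compound 2 lie within the scatter of each other.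

Compound 4 `CC1([C@H](O)/C=C/[C@@H]2C3CC(CCOCC(=O)O)=C[C@H]3C[C@H]2O)Cc2ccccc2C1` has not been measured. It differs from compound 3 by methyl in place of hydrogen on a saturated ring carbon. Among the compounds with values here, this is the same kind of change as the one from compound 1 to compound 2, but not the same: there the place was a six-membered non-aromatic ring with 2 oxygen, next to the ring oxygen, two ring bonds from the ring oxygen; here it is a five-membered non-aromatic ring of carbon only. On the basis of a single earlier step, the expectation for compound 4 in this assay is a 2.2-fold higher number from compound 3 to compound 4 (0.34 log units; beyond the scatter), a step of about the size seen in a 3.2-fold higher number from compound 1 to compound 2 (0.50 log units; beyond the scatter), with wide uncertainty because the ring that carries the change is different. The estimated value for compound 4 in this assay is 0.06 mg/kg, with a plausible range from 0.025 mg/kg to 0.15 mg/kg.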

Compound 4, dose for half-maximal effect: 0.006 mg/kg
Compound 4: middle estimate off by 10-fold (1.00 log units), on the high side; measured number outside the range, below it.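

In this assay, the new step is a 4.6-fold lower number from compound 3 to compound 4 (0.66 log units; beyond the scatter), which runs in the opposite direction to a 3.2-fold higher number from compound 1 to compound 2 (0.50 log units; beyond the scatter), so the sign of the step seen on one core did not hold on the other. Methyl in place of hydrogen on a saturated ring carbon therefore cannot be carried across these two cores as a fixed penalty or a fixed gain, and the two steps do not agree within the scatter: the same change on two cores in this assay, a 3.2-fold higher number (0.50 log units; beyond the scatter) from compound 1 to compound 2 and a 4.6-fold lower number (0.66 log units; beyond the scatter) from compound 3 to compound 4, 14-fold (1.16 log units) apart, beyond the scatter of two such steps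

Within the data shown here, this does not show why the steps differ, nor does it give a rule for other cores, as there are only two pairs and they differ both in the ring that carries the methyl, a six-membered non-aromatic ring with 2 oxygen in one case and a five-membered non-aromatic ring of carbon only in the other, and in the rest of the structure.

From the compounds shown here alone, it remains open whether the direction of the step follows the ring carrying the methyl or the remainder of the core, a question that matched pairs with the 2,3-dihydro-1H-inden-2-yl group on the core of compound 1 would address. Also open, going by these compounds, is whether a longer chain such as ethyl on the same saturated ring carbon would behave as methyl does on either core.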